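The source may hold more compounds than are shown below. What is called first, only, known or untested is meant among the compounds shown, and "the series" means these compounds.

In an ADME assay on SH-SY5Y cells (Homo sapiens) for cytotoxicity, read by MTT assay, with a stated time of 72 h (a higher number here means a weaker inhibitor, a lower number a stronger inhibitor), compound 1 `O=C(CN1CCN(C(=O)c2ccccc2)CC1)N1CCN(CCCc2c[nH]c3ccc(F)cc23)CC1` gives 146000 nM and compound 2 `COc1ccc(C(=O)N2CCN(CC(=O)N3CCN(CCCc4c[nH]c5ccc(F)cc45)CC3)CC2)cc1` gives 161000 nM as its half-maximal inhibitory concentration. Among the measured compounds shown here, compound 2 thus stands level with compound 1, the only other compound measured, and the pair cannot be ranked. Compound 3 `Cc1ccc(C(=O)N2CCN(CC(=O)N3CCN(CCCc4c[nH]c5ccc(F)cc45)CC3)CC2)cc1` has not yet been measured. It differs from compound 2 on an aromatic carbon of a six-membered aromatic ring of carbon only, para to a large group, with methyl in place of methoxy (methyl in place of methoxy on an aromatic carbon). For the measured compounds named here, one measured step bears on this, methoxy in place of hydrogen on an aromatic carbon, and it came to a 1.1-fold higher number from compound 1 to compound 2 (0.04 log units; within the scatter) in size. Going by the values given here, with only that small step to go on, no step beyond the scatter is expected in this assay in either direction. The step expected is a 1.1-fold lower number from compound 2 to compound 3 (0.03 log units; within the scatter) by this estimate. Compound 3 is expected to give 150000 nM with an estimated range from 85000 nM to 260000 nM on repeated measurement.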

Compound 3, half-maximal inhibitory concentration: 119000 nM
Estimate against measurement, compound 3: 1.3-fold (0.10 log units) above; low and high end bracket the measured number.
By their numbers in this assay, from the lowest: compounds 3, 1 and 2 (each within the scatter of the next).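

At this aromatic carbon, para to a large group, this assay now compares three substituents, with methyl joining hydrogen and methoxy: methyl in place of methoxy gives a 1.4-fold lower number from compound 2 to compound 3 (0.13 log units; within the scatter), and methyl in place of hydrogen gives a 1.2-fold lower number from compound 1 to compound 3 (0.09 log units; within the scatter). Both steps lie within the scatter, so the three compounds cannot be ranked, and removing the oxygen along with its hydrogen-bond acceptor leaves no difference that can be told from scatter. Nothing measured here offers an explanation for this result.

From the compounds shown here alone, all three substituents carry no net charge, so it remains open whether an amine, a carboxylic acid or a longer chain at this carbon would also leave the number within the scatter. Going by these compounds, it is also open whether methyl and methoxy would read the same on another carbon of this ring.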